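This account rests on a few compounds, and the source may have more. Where it says the series, first, only, none or still open, it means among the compounds named here.

In an assay on isolated protein (strain Sprague-Dawley) for inhibition of Amine oxidase [flavin-containing] A (Rattus norvegicus), read by spectrophotometry, with a stated time of 5 min, tested at 10 uM (on this read-out lower numbers stand for less inhibition and higher numbers for more inhibition at the one concentration tested (going by the name of the read-out)), compound 2 `COCOc1cc(=O)oc2cc(OCc3cccc(Cl)c3)ccc12` gives 23%, the higher of the two numbers measured, while compound 1 `CCOc1cc(=O)oc2cc(OCc3cccc(Br)c3)ccc12` gives 2.5%, a gap beyond the usual scatter. Compound 3 `O=c1cc(CCl)c2ccc(OCc3cccc(Cl)c3)cc2o1` has not been measured in this assay. It differs from compound 2 in one place: chloromethyl in place of methoxymethoxy on an aromatic carbon. Nothing measured shows what such a change does here, so the step from compound 2 to compound 3 is expected to be small, a number 3 percentage points lower from compound 2 to compound 3 (within the scatter), within the scatter in either direction. Compound 3 is therefore estimated at 20%, with a range of 2% to 45%.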

Compound 3, a percentage reported as inhibition, at one concentration (the size of the read-out at that concentration, not a potency): 21%
For compound 3 the middle estimate is 1 percentage points below the measured one, and the stated range covers the measured number.
By their numbers in this assay, from the lowest: compound 1; then compounds 3 and 2 (each within the scatter of the next).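

In this assay, chloromethyl in place of methoxymethoxy on this aromatic carbon, opposite the ring oxygen, gives a number 2 percentage points lower from compound 2 to compound 3 (within the scatter). The group that leaves carries 2 hydrogen-bond acceptors and the group that enters carries 0, so at this position, for this pair, the read-out does not depend on those acceptors. No measurement available bears on the reason for this result. On these data alone, whether an amine, a carboxylic acid or a longer alkyl chain on this carbon would keep, raise or lower the inhibition remains open.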